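Adding a second chloro to the urea aryl of compound 2

The source may report more compounds than this note shows. Statements on the series, on what has been measured and on what is new or still open speak of the compounds shown alone.

Measured compounds:
compound 1, `CN(C)CCNc1nc(-c2ccc(NC(=O)Nc3ccc(Cl)cc3Cl)cc2)nc2ccsc12`, 1650 nM
compound 2, `CCN(CC)CCNc1nc(-c2ccc(NC(=O)Nc3ccccc3Cl)cc2)nc2ccsc12`, 320 nM

In a functional assay on NCI-H460 cells (Homo sapiens) for cytotoxicity, read by MTT assay, with a stated time of 72 h (on this read-out lower numbers stand for stronger inhibition and higher numbers for weaker inhibition), compound 2 gives the lower of the two numbers, and compound 1 gives the higher one; the gap between them lies beyond the scatter. Compound 1 and compound 2 differ in two places at once, in the amine chain and in the urea aryl ring, so the numbers alone do not say which of the two accounts for the gap. Compound 3, `CCN(CC)CCNc1nc(-c2ccc(NC(=O)Nc3ccc(Cl)cc3Cl)cc2)nc2ccsc12`, keeps the amine chain of compound 2 and carries the change (chloro in place of hydrogen on an aromatic carbon), that is, chloro in place of hydrogen on an aromatic carbon. Going by the values given here, since the only measured pair with the 2,4-dichlorophenyl group is the weaker compound 1, the step from compound 2 to compound 3 is expected to move toward a higher number, though its size is uncertain. Compound 3 is expected to give 700 nM, between 250 nM and 2000 nM. The expected step of a 2.2-fold higher number from compound 2 to compound 3 (0.34 log units; beyond the scatter) is thus estimated as moderate, toward weaker inhibition.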

Compound 3, half-maximal inhibitory concentration: 1890 nM
Compound 3: the middle estimate sits 2.7-fold (0.43 log units) below what was measured; measured number inside the range.
By their numbers in this assay, from the lowest: compound 2; then compounds 1 and 3 (each within the scatter of the next).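

In this assay chloro in place of hydrogen on the urea aryl ring, turning 2-chlorophenyl into 2,4-dichlorophenyl, gives a 5.9-fold higher number from compound 2 to compound 3 (0.77 log units; beyond the scatter) and so accounts for the gap that the first two compounds could not assign to either place. The amine chain, by contrast, does not separate the compounds carrying the 2,4-dichlorophenyl group: diethylamino in place of dimethylamino gives a 1.1-fold higher number from compound 1 to compound 3 (0.06 log units; within the scatter) and stays within the scatter. Nothing at hand explains why the added chloro moves the number toward weaker inhibition.

Going by these compounds, whether fluoro, methyl or methoxy in place of this chloro would give a similar step remains open. Also open, on these data alone, is how the 2-chlorophenyl urea behaves with a dimethylamino chain, or with a longer amine chain or a morpholine at the end of the chain.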